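This account rests on a few compounds, and the source may have more. Where it says the series, first, only, none or still open, it means among the compounds named here.

Measured so far:
compound 1 `CNC(=O)c1cc(Oc2ccc(NC(=O)c3nn(-c4cccc(F)c4)c(=O)cc3C)cc2F)ccn1`, 10200 nM
compound 2 `CNC(=O)c1cc(Oc2ccc(NC(=O)c3nn(-c4ccc(C)cc4)c(=O)cc3C)cc2F)ccn1`, 10600 nM
compound 3 `Cc1cc(=O)n(-c2ccccc2C(F)(F)F)nc1C(=O)Nc1ccc(Oc2ncnc3ccsc23)cc1`, 9230 nM

In a functional assay on HepG2 cells (Homo sapiens) for cytotoxicity, read by MTT assay, with a stated time of 72 h (on this read-out lower numbers stand for stronger inhibition and higher numbers for weaker inhibition), compound 3 gives the lowest of the three numbers, yet compound 1 and compound 2 both lie within the scatter of it, so no order among them is claimed. Compound 4 `Cc1ccc(-n2nc(C(=O)Nc3ccc(Oc4ncnc5ccsc45)cc3)c(C)cc2=O)cc1` differs from compound 3 by 4-methylphenyl in place of 2-(trifluoromethyl)phenyl on an aromatic nitrogen. Among the measured compounds shown here, the one measured step that bears on this change is a 1.0-fold higher number from compound 1 to compound 2 (0.02 log units; within the scatter), where the same 4-methylphenyl entered in place of 3-fluorophenyl without moving this assay beyond its scatter. For the measured compounds named here, no measured step covers the loss of 2-(trifluoromethyl)phenyl. On that basis the expected step is a 1.1-fold higher number from compound 3 to compound 4 (0.03 log units; within the scatter), nothing beyond the scatter. The estimate for compound 4 is 10000 nM, with a range from 4000 nM to 25000 nM.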

Compound 4, half-maximal inhibitory concentration: 25000 nM
Estimate against measurement, compound 4: 2.5-fold (0.40 log units) below, and the stated range covers the measured number.
By their numbers in this assay, from the lowest: compounds 3, 1 and 2 (each within the scatter of the next); then compound 4.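

In this assay, replacing 2-(trifluoromethyl)phenyl with 4-methylphenyl on the aromatic nitrogen gave a 2.7-fold higher number from compound 3 to compound 4 (0.43 log units; beyond the scatter) and so moved the number beyond the scatter. This shows that the group at this position can matter on the core of compound 3, whereas the same group entering in place of 3-fluorophenyl gave a 1.0-fold higher number from compound 1 to compound 2 (0.02 log units; within the scatter) and stayed within the scatter. Nothing measured here explains this result.

On these data alone, whether 2-(trifluoromethyl)phenyl would have the same effect on the core of compound 1 remains open. So does how a phenyl group carrying an amine or a carboxylic acid would read.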